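The source may hold more compounds than are shown below. What is called first, only, known or untested is meant among the compounds shown, and "the series" means these compounds.

Measured series:
compound 1 `COc1ccc([C@H]2CC(c3cc4ccccc4oc3=O)=NN2c2ccccc2)cc1` — 24.8% in a functional assay on the whole organism (strain albino) for inhibition, with Rattus norvegicus as the target, read by paw edema, with stated times of 1 h and 2 h, at a dose of 200 mg/kg by the oral route; on this read-out higher numbers stand for more inhibition at the one dose given (going by the name of the read-out) and lower numbers for less inhibition
compound 2 `O=c1oc2ccccc2cc1C1=NN(c2ccccc2)[C@@H](/C=C/c2ccccc2)C1` — 26.7%
compound 3 `O=c1oc2ccccc2cc1C1=NN(c2ccccc2)[C@@H](c2cccc([N+](=O)[O-])c2)C1` — 26.1%

Compound 3 sits second of the three numbers; its nearest neighbour is compound 2 a number 0.6 percentage points lower from compound 2 to compound 3 (within the scatter) and its furthest compound 1 a number 1.3 percentage points higher from compound 1 to compound 3 (within the scatter), both within the scatter, as is a number 1.9 percentage points higher from compound 1 to compound 2 (within the scatter). Every measured step exchanges the group on the saturated ring carbon of the shared core, and none moves the read-out beyond the scatter.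

Compound 4 `O=c1oc2ccccc2cc1C1=NN(c2ccccc2)[C@@H](c2ccccc2[N+](=O)[O-])C1` differs from compound 3 at the same place: 2-nitrophenyl in place of 3-nitrophenyl on a saturated ring carbon. The three steps bear on this change directly, and all were small. No step beyond the scatter is therefore expected for compound 4 in this assay, with a number 0.1 percentage points lower from compound 3 to compound 4 (within the scatter) as the expected step. Compound 4 is estimated at 26%, between 17% and 35%.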

Compound 4, a percentage reported as inhibition, in the whole organism at one dose (the size of the read-out at that dose, not a potency): 24.7%
Beside the measured number, compound 4's estimate is 1.3 percentage points above it; the range from low to high includes it.
By their numbers in this assay, from the lowest: compounds 4, 1, 3 and 2 (each within the scatter of the next).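

In this assay, the nitro group's place on the phenyl ring now has a direct test: 2-nitrophenyl in place of 3-nitrophenyl gives a number 1.4 percentage points lower from compound 3 to compound 4 (within the scatter), so the same atoms joined differently do not separate the two compounds. Compared with the other groups on the saturated ring carbon, the new compound shows a number 2 percentage points lower from compound 2 to compound 4 (within the scatter) and a number 0.1 percentage points lower from compound 1 to compound 4 (within the scatter). No evidence on the origin of this flat result is available.

On these data alone, whether a primary amine or a carboxylic acid on this carbon would give a step beyond the scatter remains open. Changes to the phenyl group on the ring nitrogen also remain open.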